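Chloropyridinyl amide swap on a pyrazolyl aminopyrazine core

A few compounds are considered here, and "the series" means these few. Any claim that something is new, unique, unknown or untested is made for them only; others in the source may bear on it.

Measured compounds:
compound 1, `Cc1noc(C)c1-c1cnc(N)c(Oc2ccc(C(=O)Nc3ccccc3)cc2)n1`, in a functional assay on HepG2 cells (Homo sapiens) for inhibition, read by MTT assay, with a stated time of 72 h (a higher number here means a weaker inhibitor, a lower number a stronger inhibitor), gives 11800 nM
compound 2, `Cc1noc(C)c1-c1cnc(N)c(Oc2ccc(C(=O)Nc3cccc(Cl)n3)cc2)n1`, in this assay gives 35700 nM
compound 3, `Cn1cc(-c2cnc(N)c(Oc3ccc(C(=O)Nc4ccccc4)cc3)n2)cn1`, in this assay gives 11600 nM

Compound 3 has the lowest of the three numbers, though its gap to compound 1 is within the scatter, as a 1.0-fold lower number from compound 1 to compound 3 (0.01 log units; within the scatter) shows; only compound 2 stands clearly apart from it. Compound 4, `Cn1cc(-c2cnc(N)c(Oc3ccc(C(=O)Nc4ccc(Cl)cn4)cc3)n2)cn1`, differs from compound 3 in one place: 5-chloropyridin-2-yl in place of phenyl on an amide-type nitrogen. Going by the values given here, the one measured step that bears on this is the swap of the anilide for a chloropyridinyl amide on the other core, where a 3.0-fold higher number from compound 1 to compound 2 (0.48 log units; beyond the scatter) was seen. Among the compounds with values here, that step carried a 6-chloropyridin-2-yl, whereas compound 4 carries a 5-chloropyridin-2-yl, so the two changes are related but not identical, and no measured pair shows the 5-chloro isomer at all. On this basis compound 4 is expected to show a modest rise in the number, in the same direction as that step; the estimated step is a 2.4-fold higher number from compound 3 to compound 4 (0.38 log units; beyond the scatter). Compound 4 is thus estimated at 28000 nM in this assay, within a range of 10000 nM to 80000 nM.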

Compound 4, half-maximal inhibitory concentration: 24200 nM
Compound 4: the middle estimate sits 1.2-fold (0.06 log units) above what was measured, and the stated range covers the measured number.
By their numbers in this assay, from the lowest: compounds 3 and 1 (each within the scatter of the next); then compounds 4 and 2 (each within the scatter of the next).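

In this assay, putting 5-chloropyridin-2-yl in place of phenyl on the amide-type nitrogen gives a 2.1-fold higher number from compound 3 to compound 4 (0.32 log units; beyond the scatter), so the rise in the number also appears on the core of compound 3. Alongside a 3.0-fold higher number from compound 1 to compound 2 (0.48 log units; beyond the scatter), which involves the 6-chloropyridin-2-yl group on the core of compound 1, this makes two chloropyridinyl swaps that both weaken inhibition beyond the scatter, and no compound shown goes against that direction. Nothing available explains the rise.

The compounds shown leave open whether the ring nitrogen or the chlorine accounts for the step, which an unsubstituted pyridin-2-yl or a chlorophenyl group could separate. They also leave open how an amine or a carboxylic acid on this ring would behave in place of the chlorine.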